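This account rests on a few compounds, and the source may have more. Where it says the series, first, only, none or still open, it means among the compounds named here.

Measured so far:
compound 1 `C=C1C=CCO[C@@H]1n1cc(C)c(O)nc1=O` — 486000 nM
compound 2 `O=C(Nc1ccn([C@H]2OCC=CC2=O)c(=O)n1)c1ccccc1` — 28000 nM

In a functional assay on L1210 cells (Mus musculus), with a stated time of 2 days (on this read-out lower numbers stand for stronger inhibition and higher numbers for weaker inhibition), compound 2 gives the lowest of the two numbers; compound 1 gives a higher one, and that gap lies beyond the scatter. Compound 3 `C=C1C=CCO[C@@H]1n1ccc(NC(=O)c2ccccc2)nc1=O` is not yet measured. It differs from compound 2 in one place: a group of 7 heavy atoms (6 carbon, 1 oxygen; one six-membered non-aromatic ring with 1 hetero atom) in place of a group of 7 heavy atoms (5 carbon, 2 oxygen; one six-membered non-aromatic ring with 1 hetero atom), on an aromatic nitrogen. Going by the values given here, no measured pair shows this change on its own, so the step carries uncertainty. The account expects a move toward weaker inhibition, beyond the scatter, as a 3.6-fold higher number from compound 2 to compound 3 (0.55 log units; beyond the scatter). For compound 3 the estimate is 100000 nM, within a range from 20000 nM to 500000 nM.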

Compound 3, half-maximal inhibitory concentration: 368000 nM
Estimate against measurement, compound 3: 3.7-fold (0.57 log units) below, within the range that was stated.
By their numbers in this assay, from the lowest: compound 2; then compounds 3 and 1 (each within the scatter of the next).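

In this assay, going by these compounds alone, the exchange on the aromatic nitrogen gives a 13-fold higher number from compound 2 to compound 3 (1.12 log units; beyond the scatter), the first comparison in which only this group differs. With the shared core held constant, this position is therefore sensitive to the change: the entering group has a methylidene-type carbon-for-oxygen difference in heavy-atom count and one hydrogen-bond acceptor fewer, and inhibition is much weaker. No measurement here explains the step. The compounds shown leave open how a ring carrying a hydroxyl or an amine would read at this nitrogen, and whether the same exchange has a similar effect on another core.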